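The source may hold more compounds than are shown below. What is called first, only, known or untested is meant among the compounds shown, and "the series" means these compounds.

Series notes, step from compound 3 to compound 4.

Compound 1 `COc1ccc(-n2c(=O)n(Cc3cc4cc(Cl)ccc4n3CCCC#N)c3cnccc32)cc1` in an ADME assay on HeLa cells (Homo sapiens) for cytotoxicity, read by ATP content, with a stated time of 3 days (a higher number here means that more compound is tolerated, a lower number that less compound is tolerated), gives > 50000 nM, which is a limit of the assay and not a number. Compound 2 `COc1ccc(-n2c(=O)n(Cc3cc4cc(Cl)ccc4n3CCCC#N)c3cnccc32)c(F)c1` in this assay gives > 50000 nM, again a limit. Compound 3 `N#CCCCn1c(Cn2c(=O)n(-c3ccncc3F)c3ccncc32)cc2cc(Cl)ccc21` in this assay gives > 50000 nM, a limit as well. Compound 3 therefore stands where every measured member of the series stands, at the limit of > 50000 nM in this assay, at which 3 of the 3 values shown sit. The steps a step that the two limits leave unreadable from compound 1 to compound 2, a step that the two limits leave unreadable from compound 1 to compound 3 and a step that the two limits leave unreadable from compound 2 to compound 3 carry no readable size, since each pair of limits hides the difference.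

Compound 4 `COc1ccc(-n2c(=O)n(Cc3cc4cc(Cl)ccc4n3CCCC#N)c3cnccc32)cc1C` differs from compound 3 as follows: 4-methoxy-3-methylphenyl in place of 3-fluoropyridin-4-yl on an aromatic nitrogen. Within the data shown here, the steps that bear on this change are those from compound 1 and compound 2 to compound 3, both unreadable; none suggests a measurable change in this assay. For compound 4 the estimate is that the step of a number no higher from compound 3 to compound 4 (the limit leaves the size open) is expected to stay within scatter. Compound 4 is expected to give 50000 nM, in the range 25000 nM to 50000 nM, most likely again reported only as a limit.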

Compound 4, half-maximal cytotoxic concentration: > 50000 nM
Compound 4: no number, only a limit; the forecaster's own chance of this, stated with the estimate: 85%; the middle value lies on the limit itself.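

No step from compound 1, compound 2 or compound 3 to compound 4 can be read in this assay, since each pair of values is a pair of limits: the limit of > 50000 nM in this assay, at which 4 of the 4 values shown sit.

On these data alone, what stays open is the concentration at which any of these four compounds becomes cytotoxic in this assay, and so whether the changes among them matter.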